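Removing one methyl from compound 2

The source may hold more compounds than are shown below. What is called first, only, known or untested is meant among the compounds shown, and "the series" means these compounds.

In an ADME assay on L6 cells (Rattus norvegicus) for cytotoxicity, read by resazurin assay, with a stated time of 70 h (a higher number here means a weaker inhibitor, a lower number a stronger inhibitor), compound 2 `COc1cc(CN2c3ccc(OC(C)=O)cc3C(C)=CC2(C)C)cc(OC)c1` gives 25000 nM, close to compound 3 `COc1cccc(CN2c3ccc(OC(C)=O)cc3C(C)=CC2(C)C)c1` at 29000 nM, while compound 1 `COc1cc(CN2c3ccc(O)cc3C(C)=CC2(C)C)cc(OC)c1` gives a lower number, 11000 nM. Compound 4 `COc1cc(CN2c3ccc(OC(C)=O)cc3C=CC2(C)C)cc(OC)c1` carries a single change: hydrogen in place of methyl on a double-bonded ring carbon, which is hydrogen in place of methyl on a double-bonded ring carbon. Two measured steps offer context. One is the modest 2.3-fold higher number from compound 1 to compound 2 (0.36 log units; beyond the scatter), made by adding acetyl on an oxygen, and the other is a 1.2-fold higher number from compound 2 to compound 3 (0.06 log units; within the scatter), made by removing a methoxy. Neither touches that ring carbon, so they bear on it only indirectly, and no step beyond the scatter is expected in this assay: the expected change is a 1.1-fold lower number from compound 2 to compound 4 (0.04 log units; within the scatter). Compound 4 is estimated at 23000 nM, with an expected range of 11000 nM to 48000 nM.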

Compound 4, half-maximal inhibitory concentration: 10000 nM
For compound 4 the middle estimate is 2.3-fold (0.36 log units) above the measured one, outside the stated range (below it).
By their numbers in this assay, from the lowest: compounds 4 and 1 (each within the scatter of the next); then compounds 2 and 3 (each within the scatter of the next).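

Putting hydrogen in place of methyl on this double-bonded ring carbon gives a 2.5-fold lower number from compound 2 to compound 4 (0.40 log units; beyond the scatter) in this assay. Among the compounds shown here, this is the first sign that this part of the shared core affects the number, since the earlier steps changed only the oxygen on the aromatic ring or a methoxy. Nothing available explains the shift. Going by these compounds, whether ethyl or fluorine on this carbon would move the number the same way remains open. So does whether removing the methyl would have a similar effect in compound 1 or compound 3.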